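Cyclopropyl to propyl on the ring nitrogen: compound 4

A few compounds are considered here, and "the series" means these few. Any claim that something is new, unique, unknown or untested is made for them only; others in the source may bear on it.

In an assay on isolated protein for inhibition of Gonadotropin-releasing hormone receptor (Homo sapiens) (on this read-out higher numbers stand for weaker inhibition and lower numbers for stronger inhibition), compound 1 `COc1ccccc1CSc1nc2cc(NC(=O)C3CC3)ccc2n1C(C)C` gives 2100 nM, compound 2 `COc1ccc(C(C)=O)cc1CSc1nc2cc(NC(=O)C3CC3)ccc2n1C(C)C` gives 260 nM and compound 3 `COc1ccc([N+](=O)[O-])cc1CSc1nc2cc(NC(=O)NC(C)(C)C)ccc2n1C1CC1` gives 79 nM. Compound 3 stands lowest of the three, beyond the scatter from both others. Going by the values given here, the only single-point step measured, an 8.1-fold lower number from compound 1 to compound 2 (0.91 log units; beyond the scatter), concerns a substituent on an aromatic carbon and does not bear on the change now made. Compound 4 `CCCn1c(SCc2cc([N+](=O)[O-])ccc2OC)nc2cc(NC(=O)NC(C)(C)C)ccc21` differs from compound 3 by propyl in place of cyclopropyl on an aromatic nitrogen. Among the compounds with values here, no measured pair isolates the group on this ring nitrogen; compounds 1 and 2 carry a different group there, so nothing in the data points either way. The expected step is a 1.3-fold higher number from compound 3 to compound 4 (0.10 log units; within the scatter), within the scatter. Compound 4 is estimated at 100 nM, with a range from 35 nM to 300 nM.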

Compound 4, half-maximal inhibitory concentration: 18 nM
The estimate for compound 4 lay 5.6-fold (0.74 log units) above the measured number; the whole stated range lies above it.
By their numbers in this assay, from the lowest: compound 4; then compound 3; then compound 2; then compound 1.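

In this assay, the group on this ring nitrogen proves to matter: propyl in place of cyclopropyl gives a 4.4-fold lower number from compound 3 to compound 4 (0.64 log units; beyond the scatter), the first step measured at this position. Both groups have 3 heavy atoms, so the step goes with loss of the ring and not with a change in that count. Nothing measured gives a reason for the step.

As far as these compounds go, whether a longer chain such as butyl on this nitrogen lowers the number further remains open. Also open, from the compounds shown here alone, is whether the step holds with the acetyl and cyclopropyl amide groups of compound 2.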